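A few compounds are considered here, and "the series" means these few. Any claim that something is new, unique, unknown or untested is made for them only; others in the source may bear on it.

In a functional assay on HEK293 cells for activation of melanin-concentrating hormone receptor 1 (Homo sapiens), read by inositol phosphate accumulation (a higher number here means that more compound is needed for the effect, a lower number that less compound is needed), compound 1 `CCc1cc(N)c2cc(NC(=O)/C=C/c3ccc(C(F)(F)F)cc3)ccc2n1` gives 110 nM, and compound 3 `CC(C)(C)c1cc(N)c2cc(NC(=O)/C=C/c3ccc(C(F)(F)F)cc3)ccc2n1` gives 29 nM. For the measured compounds named here, the one step, a 3.8-fold lower number from compound 1 to compound 3 (0.58 log units; beyond the scatter), concerns the shared core and leaves the trifluoromethylphenyl group untouched. Compound 2 `CCCc1cc(N)c2cc(NC(=O)/C=C/c3ccc(Cl)cc3Cl)ccc2n1` gives 904 nM in this assay, the highest of the three numbers, with compound 1 nearest and compound 3 furthest. Compound 4 `CCCc1cc(N)c2cc(NC(=O)/C=C/c3ccc(Cl)c(Cl)c3)ccc2n1` differs from compound 2 by 3,4-dichlorophenyl in place of 2,4-dichlorophenyl on a double-bonded chain carbon bound to a double-bonded chain carbon. Going by the values given here, no measured pair in this set alters the dichlorophenyl group, so the single recorded step gives no guide to the size or direction of this change. With nothing pointing either way, the expectation for compound 4 in this assay is a number near that of compound 2, and the step of a 1.3-fold lower number from compound 2 to compound 4 (0.11 log units; within the scatter) is expected to stay within the scatter. The estimate for compound 4 in this assay is 700 nM, with a range from 200 nM to 2500 nM.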

Compound 4, half-maximal effective concentration: 990 nM
Beside the measured number, compound 4's estimate is 1.4-fold (0.15 log units) below it, and the stated range covers the measured number.
By their numbers in this assay, from the lowest: compound 3; then compound 1; then compounds 2 and 4 (each within the scatter of the next).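

In this assay, for the compounds shown here, 3,4-dichlorophenyl in place of 2,4-dichlorophenyl on a double-bonded chain carbon bound to a double-bonded chain carbon gives a 1.1-fold higher number from compound 2 to compound 4 (0.04 log units; within the scatter), the first measured step at this position, and compound 2 and compound 4 cannot be told apart. Between these two dichlorophenyl groups, the arrangement of the two chlorines therefore makes no readable difference, whereas the step on the shared core, a 3.8-fold lower number from compound 1 to compound 3 (0.58 log units; beyond the scatter), lies beyond the scatter. No supporting data bear on why this exchange leaves the number within the scatter.

On these data alone, whether a single chlorine, a methoxy group or an amine on this phenyl ring would also stay within the scatter remains open. Also open, as far as these compounds go, is whether tert-butyl in place of the propyl chain would shift the dichlorophenyl compounds as it shifts the trifluoromethylphenyl pair.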